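Hydrogen in place of hydroxy on compound 1

The source may report more compounds than this note shows. Statements on the series, on what has been measured and on what is new or still open speak of the compounds shown alone.

In an ADME assay on MCF7-DOX cells (Homo sapiens) for cytotoxicity, read by MTT assay, with a stated time of 48 h (on this read-out lower numbers stand for stronger inhibition and higher numbers for weaker inhibition), compound 1, `COc1cc(O)c(C(=O)/C=C/c2cccc(N3CCNCC3)c2)c(OC)c1`, gives 99200 nM, the only actual number shown so far. Compound 2, `CCCCCc1c(OC)cc(OC)c(C(=O)/C=C/c2cccc(N3CCNCC3)c2)c1O`, gives > 100000 nM, which is a limit and not a number. Compound 3, `COc1ccc(C(=O)/C=C/c2cccc(N3CCNCC3)c2)c(OC)c1`, carries hydrogen in place of hydroxy on an aromatic carbon of compound 1: hydrogen in place of hydroxy on an aromatic carbon. For the measured compounds named here, the one measured step, a number no lower from compound 1 to compound 2 (the limit leaves the size open), has no readable size and is a different change, pentyl in place of hydrogen, so it offers no size to carry over. No shift beyond the scatter is expected in this assay, the expected change being a 1.2-fold lower number from compound 1 to compound 3 (0.09 log units; within the scatter). The estimated value for compound 3 is 80000 nM, with a range of 30000 nM to 100000 nM.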

Compound 3, half-maximal inhibitory concentration: 95000 nM
For compound 3 the middle estimate is 1.2-fold (0.07 log units) below the measured one, and the stated range covers the measured number.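

In this assay, hydrogen in place of hydroxy on this aromatic carbon gives a 1.0-fold lower number from compound 1 to compound 3 (0.02 log units; within the scatter). For the compounds shown here, this is the first step with a readable size, and it shows that the hydroxy can leave without a shift beyond the scatter. Little room remains to read any loss at this position: the limit of > 100000 nM in this assay, at which 1 of the 3 values shown sits.

Left open is whether an amine or a carboxylic acid on this aromatic carbon would move the number beyond the scatter relative to compound 3.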